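Notes on a fluoro to methyl exchange

The source may report more compounds than this note shows. Statements on the series, on what has been measured and on what is new or still open speak of the compounds shown alone.

Of the compounds shown here, two carry numbers so far in a functional assay on SK-BR-3 cells (Homo sapiens) for cytotoxicity, read by sulforhodamine B assay, with a stated time of 72 h; on this read-out lower numbers stand for an effect already at smaller amounts and higher numbers for an effect only at larger amounts of compound. Compound 1 (`Cc1coc2cc(-c3cccc(O)c3)oc(=O)c12`) gives 1.61 uM in this series. Compound 2 (`Cc1coc2cc(-c3ccc(F)cc3)oc(=O)c12`) gives 19.3 uM and holds the higher of the two numbers, with a gap to compound 1 that lies beyond the usual scatter. Compound 3 (`Cc1ccc(-c2cc3occ(C)c3c(=O)o2)cc1`) is the next to be read. Going from compound 2 to compound 3 (methyl in place of fluoro on an aromatic carbon) puts methyl in place of fluoro on an aromatic carbon, para to a large group. Within the data shown here, no measured pair shows this exchange, so the expectation has only compound 2 at 19.3 uM as its anchor. In this assay no step beyond the scatter is expected, perhaps a slightly lower number. The estimated step of a 1.3-fold lower number from compound 2 to compound 3 (0.11 log units; within the scatter) stays within that scatter. The estimate for compound 3 is 15 uM (expected range 6 uM to 40 uM).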

Compound 3, concentration for half-maximal effect: > 83.3 uM
Compound 3 gave a limit, no number; the forecaster's own chance of this, stated with the estimate: 10%; middle value at least 5.5-fold (0.74 log units) away from the limit.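

On this aromatic carbon, para to a large group, methyl in place of fluoro gives an at least 4.3-fold higher number from compound 2 to compound 3 (0.63 log units; beyond the scatter) in this assay. This one-atom exchange leaves the ring count, the net charge and the hydrogen-bond donor and acceptor counts unchanged, yet it is enough to move the read-out, so this position responds to the group it carries, which compound 2 alone could not show. The reading for compound 3 is a limit of the assay and not a number, so the step has a floor but no known size: the limit of > 83.3 uM in this assay, at which 1 of the 3 values shown sits.

The compounds shown leave open how a chloro group, a methoxy group or an amine on the same carbon would read, and whether hydrogen there would sit nearer compound 2 or compound 3. What lies behind the step also stays open, as no property of fluoro or methyl is measured here.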